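Adding a Second Chlorine to a Weakly Active Dithiocarbamate

The compounds below may be only part of what the source reports. "The series", "measured", "known", "first", "only" and "open" are said of these compounds alone.

Of the compounds shown here, three that share one core have been tested in a functional assay on ECa-109 cells (Homo sapiens) for inhibition, read by MTT assay, with a stated time of 72 h; on this read-out higher numbers stand for weaker inhibition and lower numbers for stronger inhibition. Compound 1 `COc1ccc(-n2cc(CSC(=S)N3CCN(C(=O)OC(C)(C)C)CC3)nn2)cc1` gives only a limit, > 128000 nM, in this assay. Compound 2 `O=C(OCc1ccccc1)N1CCN(C(=S)SCc2cn(Cc3ccc(Cl)cc3)nn2)CC1` likewise reaches only the limit of > 128000 nM. Compound 3 `Fc1ccccc1Cn1cc(CSC(=S)N2CCNCC2)nn1` also stops at the limit of > 128000 nM. So compound 2 stands nowhere on a numbered scale: its value is a limit, and every value shown sits at the same limit, as the limit of > 128000 nM in this assay, at which 3 of the 3 values shown sit, records.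

Compound 4 `O=C(OCc1ccccc1)N1CCN(C(=S)SCc2cn(Cc3ccc(Cl)c(Cl)c3)nn2)CC1` differs from compound 2 by a single change: chloro in place of hydrogen on an aromatic carbon. Within the data shown here, no measured pair shows what such a change does here, so no step beyond the scatter is expected; the expected step from compound 2 to compound 4 is a step that the limit leaves unreadable from compound 2 to compound 4. Compound 4 is estimated at 150000 nM, within 40000 nM to 500000 nM.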

Compound 4, half-maximal inhibitory concentration: 29400 nM
For compound 4 the middle estimate is 5.1-fold (0.71 log units) above the measured one; the whole stated range lies above it.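

Placing chloro on an aromatic carbon ortho to a chloro group, which turns 4-chlorobenzyl into 3,4-dichlorobenzyl, brings a readable number in this assay: the change gives an at least 4.3-fold lower number from compound 2 to compound 4 (0.63 log units; beyond the scatter). On these data alone, compound 2 gives only a limit, > 128000 nM, so the full size of this step stays unknown. The earlier compounds could not show that this position affects the read-out, since all of them stopped at one value: the limit of > 128000 nM in this assay, at which 3 of the 4 values shown sit.

As far as these compounds go, whether chloro itself matters remains open, since a methyl, a trifluoromethyl or an amine at this position could do the same or nothing. From the compounds shown here alone, it is also open whether the change would help with a different group at the other end of the shared core.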